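Ethyl to Trifluoromethyl on the Aryl Ketone End

The compounds below may be only part of what the source reports. "The series", "measured", "known", "first", "only" and "open" are said of these compounds alone.

Measured so far:
- compound 1 `O=C(/C=C/c1ccc2c(c1)B(O)OC2)c1ccc(F)cc1` gives 2800 nM in a functional assay on HCT-116 cells (Homo sapiens) for cytotoxicity, read by MTT assay, with a stated time of 48 h; on this read-out lower numbers stand for stronger inhibition and higher numbers for weaker inhibition
- compound 2 `CCc1ccc(C(=O)/C=C/c2ccc3c(c2)B(O)OC3)cc1` gives 10900 nM in this assay

Compound 2 stands at the highest of the two numbers seen in this assay; its nearest neighbour is compound 1, and the step from compound 1 to compound 2 is a 3.9-fold higher number from compound 1 to compound 2 (0.59 log units; beyond the scatter), which arose from ethyl in place of fluoro on an aromatic carbon.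

Compound 3 `O=C(/C=C/c1ccc2c(c1)B(O)OC2)c1ccc(C(F)(F)F)cc1` is not yet measured. It differs from compound 2 in one place: trifluoromethyl in place of ethyl on an aromatic carbon. Among the measured steps only the one from compound 1 to compound 2 touches this same position of the shared core, and it was a modest one. Going by the values given here, no measured step covers the exchange of ethyl for trifluoromethyl itself, so the direction can only be guessed from the fact that both neighbours at this position gave numbers of the same order. For compound 3 the expected result in this assay is therefore a number close to that of compound 2, with a slight lean downward, a step of a 1.8-fold lower number from compound 2 to compound 3 (0.26 log units; within the scatter). Compound 3 is estimated at 6000 nM, with a range from 2000 nM to 18000 nM.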

Compound 3, half-maximal inhibitory concentration: 6300 nM
For compound 3 the middle estimate is 1.1-fold (0.02 log units) below the measured one, and the stated range covers the measured number.
By their numbers in this assay, from the lowest: compound 1; then compounds 3 and 2 (each within the scatter of the next).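

In this assay, trifluoromethyl in place of ethyl gives a 1.7-fold lower number from compound 2 to compound 3 (0.24 log units; within the scatter), so at this position, para to a large group, the data do not separate these two groups, even though ethyl has 2 heavy atoms, all carbon, and trifluoromethyl has 4, three of them fluorine. The new compound also shows that the earlier gap was not specific to ethyl: trifluoromethyl in place of fluoro gives a 2.3-fold higher number from compound 1 to compound 3 (0.35 log units; beyond the scatter), a modest change in the same direction as a 3.9-fold higher number from compound 1 to compound 2 (0.59 log units; beyond the scatter), which leaves compound 1, with fluoro, with the lowest number of the three and thus the strongest inhibition in this set. Nothing available here bears on what lies behind these numbers.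

As far as these compounds go, it remains open whether an amine, a carboxylic acid or a longer chain such as propyl at this position would give a number close to that of compound 1 or closer to those of compound 2 and compound 3. These three compounds also cannot show whether the same ranking would hold if the core were changed elsewhere.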